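Propyl to Isopropyl on a Core Without Measurable Inhibition

The source may report more compounds than this note shows. Statements on the series, on what has been measured and on what is new or still open speak of the compounds shown alone.

Compound 1 `CCCc1cnc(Nc2cc[nH]n2)n2c(CCC)nc(C)c12` gives in a functional assay for inhibition, with Homo sapiens as the target (a lower number here means a stronger inhibitor, a higher number a weaker inhibitor), only a limit, > 48000 nM.
Compound 2 `CCn1ncc2c(C)nc(C(C)C)n2c1=O` gives in this assay only a limit, > 48000 nM.
Compound 3 `CCCc1nc(C)c2cnn(CC)c(=O)n12` gives in this assay only a limit, > 48000 nM.

Compound 3 and compound 2 differ in one place, (isopropyl in place of propyl on an aromatic carbon). The step that the two limits leave unreadable from compound 3 to compound 2 cannot be sized, since the limit of > 48000 nM in this assay, at which 3 of the 3 values shown sit, covers both compounds. The difference between the core of compound 1 and the core of compound 3 is not broken down here.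

Compound 4 `CCCc1nc(C)c2c(C(C)C)cnc(Nc3cc[nH]n3)n12` has not yet been measured in this assay. It differs from compound 1 by isopropyl in place of propyl on an aromatic carbon. Going by the values given here, this is the same kind of change as the one from compound 3 to compound 2, but not the same: there the place was a five-membered aromatic ring with 2 nitrogen, between two ring nitrogen atoms, whereas in compound 4 it is a six-membered aromatic ring with 2 nitrogen, para to a (1H-pyrazol-3-yl)amino group.

Among the compounds with values here, the step that the limit leaves unreadable from compound 1 to compound 4 is expected to be small, because the only measured step of this kind, a step that the two limits leave unreadable from compound 3 to compound 2, showed no readable effect and compound 1 sits at the limit of > 48000 nM in this assay, at which 3 of the 3 values shown sit. Compound 4 is therefore estimated at 70000 nM, with a range from 20000 nM to 250000 nM, most likely again only a limit.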

Compound 4, half-maximal inhibitory concentration: > 48000 nM
Compound 4: only a limit was reported (the forecaster's own chance of this, stated with the estimate: 80%); the middle value is on the limit's open side.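

Compound 1 and compound 4 both give only a limit in this assay, so the step between them cannot be read: the limit of > 48000 nM in this assay, at which 4 of the 4 values shown sit.

The compounds shown leave open whether isopropyl in place of propyl changes inhibition on either core, and whether any compound with the core of compound 1 gives a measurable value.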